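Moving the Methoxy Group to the Other Side

The source may hold more compounds than are shown below. What is called first, only, known or untested is meant among the compounds shown, and "the series" means these compounds.

Three compounds share one core. In a functional assay on Ehrlich cells (Mus musculus) for antiproliferative activity, read by trypan blue exclusion, with a stated time of 2 h, tested at 10 ug/mL (a higher number here means a stronger effect of the compound at the concentration tested, a lower number a weaker effect), compound 1 `N#CC1=C(N)N(c2ccc(S(N)(=O)=O)cc2)C2=C(C(=O)CCC2)C1c1ccccc1` gives 10%, compound 2 `N#CC1=C(N)N(c2ccc(S(N)(=O)=O)cc2)C2=C(C(=O)CCC2)C1c1ccc(O)cc1` gives 90%, and compound 3 `COc1ccccc1C1C(C#N)=C(N)N(c2ccc(S(N)(=O)=O)cc2)C2=C1C(=O)CCC2` gives 0%. Compound 3 thus sits within the scatter of compound 1, the step being a number 10 percentage points lower from compound 1 to compound 3 (within the scatter), while it lies far beneath compound 2, the step being a number 90 percentage points lower from compound 2 to compound 3 (beyond the scatter).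

Compound 4 `COc1ccc(C2C(C#N)=C(N)N(c3ccc(S(N)(=O)=O)cc3)C3=C2C(=O)CCC3)cc1` differs from compound 3 only in how the same atoms are joined: 4-methoxyphenyl in place of 2-methoxyphenyl on a saturated ring carbon. Among the measured compounds shown here, no measured step tests a methoxy group in this new place. What is known is that a hydroxy group on the aromatic carbon gave a large rise, a number 80 percentage points higher from compound 1 to compound 2 (beyond the scatter), whereas the methoxy group in its old place changed nothing beyond the scatter, a number 10 percentage points lower from compound 1 to compound 3 (within the scatter). A methoxy group is not a hydroxy group, so the outcome for compound 4 is uncertain, but an upward step is expected, a number 40 percentage points higher from compound 3 to compound 4 (beyond the scatter). The estimate for compound 4 in this assay is therefore 40%, with a range from 5% to 85%.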

Compound 4, a percentage reported as activity, at one concentration (the size of the read-out at that concentration, not a potency): 30%
The estimate for compound 4 lay 10 percentage points above the measured number; the range from low to high includes it.
By their numbers in this assay, from the lowest: compounds 3 and 1 (each within the scatter of the next); then compound 4; then compound 2.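

Where the methoxy group sits on the aromatic ring matters in this assay: swapping 2-methoxyphenyl for 4-methoxyphenyl gives a number 30 percentage points higher from compound 3 to compound 4 (beyond the scatter). In this new arrangement the methoxy group also registers against the hydrogen of the unsubstituted ring, with a number 20 percentage points higher from compound 1 to compound 4 (beyond the scatter), yet it falls well short of the free hydroxy group, since methyl in place of the hydrogen on that oxygen gives a number 60 percentage points lower from compound 2 to compound 4 (beyond the scatter). Nothing at hand explains why either change has the effect it does.

From the compounds shown here alone, it remains open whether a 4-aminophenyl or 4-carboxyphenyl group would reach the level of the 4-hydroxyphenyl group in compound 2. Also open, going by these compounds, is whether a 2-hydroxyphenyl group would sit as low as the 2-methoxyphenyl group in compound 3.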